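The source may report more compounds than this note shows. Statements on the series, on what has been measured and on what is new or still open speak of the compounds shown alone.

Among the measured compounds shown here, compound 2 `CC(=O)c1ccc(OCC(=O)Nc2ccc(C(=O)/C=C/c3ccc(Cl)cc3)cc2)cc1` gives 43% in a functional assay on the whole organism (strain albino) for inhibition, with Rattus norvegicus as the target, read by paw edema, with stated times of 30 min and 1 h, at a dose of 100 mg/kg by the oral route (on this read-out higher numbers stand for more inhibition at the one dose given (going by the name of the read-out) and lower numbers for less inhibition), the higher of the two numbers known; compound 1 `COc1ccc(/C=C/C(=O)c2ccc(NC(=O)CO[N+](=O)[O-])cc2)cc1` gives 33%, and the gap between the two lies within the scatter. Compound 3 `COc1ccc(/C=C/C(=O)c2ccc(NC(=O)COc3ccc(C(C)=O)cc3)cc2)cc1` differs from compound 2 by methoxy in place of chloro on an aromatic carbon. For the measured compounds named here, no step between measured compounds is known, so the size of this change cannot be read from any pair. Compound 3 is expected to show a step of a number 3 percentage points lower from compound 2 to compound 3 (within the scatter), none beyond the scatter. Compound 3 is therefore estimated at 40% in this assay, between 25% and 55%.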

Compound 3, a percentage reported as inhibition, in the whole organism at one dose (the size of the read-out at that dose, not a potency): 28%
Estimate against measurement, compound 3: 12 percentage points above; the measured number falls inside the stated range.
By their numbers in this assay, from the lowest: compounds 3, 1 and 2 (each within the scatter of the next, the first and the last beyond it).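

In this assay, methoxy in place of chloro on this aromatic carbon gives a number 15 percentage points lower from compound 2 to compound 3 (beyond the scatter), the first evidence from a matched pair that the read-out responds to the group at this position. The change of 4-acetylphenyl in place of nitro on an oxygen on a saturated carbon gives a number 5 percentage points lower from compound 1 to compound 3 (within the scatter), so that exchange shows no change that can be told from scatter. Nothing available accounts for the step at the aromatic carbon.

Going by these compounds, whether fluoro or an amine at this position would stay close to chloro or to methoxy remains open. On these data alone, it is also open whether the same step would appear with nitro in place of 4-acetylphenyl.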